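The source may report more compounds than this note shows. Statements on the series, on what has been measured and on what is new or still open speak of the compounds shown alone.

Working notes on the series, followed along the step from compound 1 to compound 4.

Compound 1 `O=C(Nc1cccc(-c2nc3ccccc3s2)c1)c1cc([N+](=O)[O-])ccc1Cl` was run in an ADME assay on HEK293 cells (Homo sapiens) for cytotoxicity, with a stated time of 72 h (a lower number here means that less compound is needed, a higher number that more compound is needed for the effect), and gave > 27000 nM, which is a limit of the assay and not a number. Within the same set, compound 2 `O=C(Nc1ccc(Cl)c(-c2nc3ccccc3s2)c1)c1cc([N+](=O)[O-])ccc1Cl` gave > 25000 nM in this assay, likewise a limit. Compound 3 `O=C(Nc1cccc(-c2nc3ccccc3[nH]2)c1)c1cc([N+](=O)[O-])ccc1Cl` gave > 27000 nM in this assay, again a limit. Because the reported values sit at the limit of > 25000 nM in this assay, at which 1 of the 3 values shown sits, and at the limit of > 27000 nM in this assay, at which 2 of the 3 values shown sit, every measured compound stands at a limit, so compound 1 cannot be placed against the others beyond that.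

Two measured steps start from compound 1. The change of chloro in place of hydrogen on an aromatic carbon gives a step that the two limits leave unreadable from compound 1 to compound 2, and the change of 1H-benzimidazol-2-yl in place of 1,3-benzothiazol-2-yl on an aromatic carbon gives a step that the two limits leave unreadable from compound 1 to compound 3. Neither step is readable in size or direction.

Compound 4 `Cc1ccc(-c2nc3ccccc3s2)cc1NC(=O)c1cc([N+](=O)[O-])ccc1Cl` differs from compound 1 by methyl in place of hydrogen on an aromatic carbon. Going by the values given here, no measured step bears on this change directly, and the two steps that are known are unreadable, so no direction beyond the scatter can be expected. Given that compound 1 stands at a limit with > 27000 nM, compound 4 is expected to return a further limit, estimated at 30000 nM with a range of 12000 nM to 80000 nM. The step this estimate means is a step that the limit leaves unreadable from compound 1 to compound 4, expected to lie within the scatter.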

Compound 4, half-maximal effective concentration: > 14000 nM
Compound 4 ended at the assay's limit; the forecaster's own chance of this, stated with the estimate: 85%; the middle value lies beyond the limit too.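

In this assay compound 4 gives > 14000 nM, which is a limit of the assay and not a number. Compound 1 also stands at a limit, so the comparison of compound 1 with compound 4 yields no readable step. The compounds shown leave open what half-maximal effective concentration any of them would reach in this assay, and whether methyl in place of hydrogen changes it at all.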